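Fluoro on the pendant aryl of the styryl analogue

The source may hold more compounds than are shown below. What is called first, only, known or untested is meant among the compounds shown, and "the series" means these compounds.

Two members of this indole-type series have been read so far in a functional assay on HeLa cells (Homo sapiens) for cytotoxicity, read by MTT assay, with a stated time of 2 days, tested at 10 uM; a higher number here means a weaker effect of the compound at the concentration tested, a lower number a stronger effect. Compound 1 `CC(=O)c1cc(-c2ccccc2)cc2cc(-c3ccc(F)cc3)[nH]c12` gives 76.9% in this assay. Compound 2 `CC(=O)c1cc(/C=C/c2ccccc2)cc2cc(-c3ccccc3)[nH]c12` gives 52.5% in this assay, the lowest of the two numbers shown, and the value of compound 1 lies above it by a gap beyond the usual scatter. Within the data shown here, compound 1 and compound 2 differ in two places, so no single step can be assigned between them; only the two readings themselves stand.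

Compound 3 `CC(=O)c1cc(/C=C/c2ccccc2)cc2cc(-c3ccc(F)cc3)[nH]c12` is the next analogue. It differs from compound 2 by fluoro in place of hydrogen on an aromatic carbon. Among the measured compounds shown here, no measured pair shows this change on its own, so there is no step to lean on. The expectation is that this fluoro for hydrogen exchange moves the reading little, in either direction, and stays within the scatter of repeats. For compound 3 the estimated step from compound 2 is a number 2.5 percentage points higher from compound 2 to compound 3 (within the scatter) in this assay. Compound 3 is therefore expected to give about 55% in this assay, with a likely range from 38% to 72%.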

Compound 3, a percentage reported as activity, at one concentration (the size of the read-out at that concentration, not a potency): 51.9%
Estimate against measurement, compound 3: 3.1 percentage points above, and the stated range covers the measured number.
By their numbers in this assay, from the lowest: compounds 3 and 2 (each within the scatter of the next); then compound 1.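

In this assay, phenyl to 4-fluorophenyl with 2-phenylethenyl held constant gives a number 0.6 percentage points lower from compound 2 to compound 3 (within the scatter), so the two readings cannot be told apart and fluoro at this place, para to a large group, is tolerated in this single background. Among these compounds, with 4-fluorophenyl held constant, 2-phenylethenyl in place of phenyl gives a number 25 percentage points lower from compound 1 to compound 3 (beyond the scatter), the first step that is read at one place and lies beyond the scatter, which marks the 2-phenylethenyl site as the one of the two sites that responds here. No measurement available on these compounds bears on the reason for either step.

As far as these compounds go, whether the fluoro exchange reads the same with phenyl in place of 2-phenylethenyl stays open, since the step is available in one background only. Also open, from the compounds shown here alone, is how the same aromatic carbon responds to a larger or differently built substituent, such as chloro, methoxy or an amine, and whether a longer chain in place of 2-phenylethenyl extends or loses the step seen at that site.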